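The source may hold more compounds than are shown below. What is called first, only, known or untested is meant among the compounds shown, and "the series" means these compounds.

Measured compounds:
Compound 1, `O=C(c1ccccc1)c1ccc(NC(=O)c2cc(Cl)ccc2O)cc1`, gives < 50000 nM in a physicochemical assay for solubility, read by spectrophotometry (a lower number here means a less soluble compound, a higher number a more soluble compound), and this is a limit of the assay rather than a number.
Compound 2, `O=C(c1ccccc1)c1ccc(NC(=O)c2cc(Br)ccc2O)cc1`, gives < 50000 nM in this assay, again a limit rather than a number.
Compound 3, `O=C(NCCCCl)Oc1ccc(Cl)cc1C(=O)Nc1ccc(C(F)(F)F)cc1`, gives < 50000 nM in this assay, also a limit.

Compounds 1 and 2 share one core and differ in a single place: bromo in place of chloro on an aromatic carbon. The step that the two limits leave unreadable from compound 1 to compound 2 is left unreadable by the two limits, so its size stays hidden. Going by the values given here, all that the measurements show is the limit of < 50000 nM in this assay, at which 3 of the 3 values shown sit, which sets a ceiling on solubility for every compound measured so far.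

Compound 3 has a different core from compound 1; the difference between the two cores is not broken down here. Compound 4, `O=C(NCCCCl)Oc1ccc(Br)cc1C(=O)Nc1ccc(C(F)(F)F)cc1`, is not yet measured and stands to compound 3 as compound 2 stands to compound 1: bromo in place of chloro on an aromatic carbon. It is the same kind of change rather than the same change, since the surroundings differ: in compound 1 the carbon is para to a hydroxy group, while in compound 3 it is para to a ((3-chloropropyl)carbamoyl)oxy group.

The expectation for compound 4 rests on compound 3, whose value < 50000 nM is a limit. Compound 4 is expected to give 20000 nM in this assay, with a likely range from 3000 nM to 50000 nM. The expected step that the limit leaves unreadable from compound 3 to compound 4 is an estimate only, and a further limit is the most probable outcome.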

Compound 4, solubility: < 50000 nM
Compound 4: no number, only a limit; the forecaster's own chance of this, stated with the estimate: 85%; the middle value lies beyond the limit too.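

Compound 3 and compound 4 both rest at a limit of the assay rather than at a number, so the step between them, bromo in place of chloro, cannot be read. The same holds for every compound shown: the limit of < 50000 nM in this assay, at which 4 of the 4 values shown sit. On these data alone, what stays open is the actual solubility of each compound in this assay and whether bromo in place of chloro alters it at all.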